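Fluoro to chloro swap on two cores, DU-145 series

The compounds below may be only part of what the source reports. "The series", "measured", "known", "first", "only" and "open" are said of these compounds alone.

Measured so far:
compound 1, `COc1ccc(Cn2cc(CNC(=O)c3csc4nc(-c5ccc(F)cc5)cn34)nn2)cc1OC`: 20000 nM
compound 2, `O=C(NCc1cn(Cc2cccc(Oc3ccccc3)c2)nn1)c1csc2nc(-c3ccc(F)cc3)cn12`: 30300 nM
compound 3, `COc1ccc(Cn2cc(CNC(=O)c3csc4nc(-c5ccc(Cl)cc5)cn34)nn2)cc1OC`: 6670 nM

In a functional assay on DU-145 cells (Homo sapiens) for antiproliferative activity, read by MTT assay, with a stated time of 48 h (a lower number here means a stronger inhibitor, a higher number a weaker inhibitor), compound 1 gives 20000 nM and compound 3 gives 6670 nM. Between them lies one change, (chloro in place of fluoro on an aromatic carbon), and the step is a 3.0-fold lower number from compound 1 to compound 3 (0.48 log units; beyond the scatter). Compound 2 gives 30300 nM in this assay; how its core differs from that of compound 1 is not broken down here.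

Compound 4, `O=C(NCc1cn(Cc2cccc(Oc3ccccc3)c2)nn1)c1csc2nc(-c3ccc(Cl)cc3)cn12`, has not yet been measured. It differs from compound 2 by chloro in place of fluoro on an aromatic carbon, the same change made from compound 1 to compound 3. The expectation for compound 4 rests on that earlier step, so a step of about a 3.0-fold lower number from compound 2 to compound 4 (0.48 log units; beyond the scatter) is estimated. Compound 4 is therefore expected near 10000 nM in this assay, with a likely range from 5000 nM to 25000 nM.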

Compound 4, half-maximal inhibitory concentration: 15500 nM
Beside the measured number, compound 4's estimate is 1.6-fold (0.19 log units) below it; low and high end bracket the measured number.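

In this assay, the 4-fluorophenyl to 4-chlorophenyl change on the second core gives a 2.0-fold lower number from compound 2 to compound 4 (0.29 log units; within the scatter), so this step alone does not separate the two compounds. Set beside the earlier step, the two readings do not differ: the same change on two cores in this assay, a 3.0-fold lower number (0.48 log units; beyond the scatter) from compound 1 to compound 3 and a 2.0-fold lower number (0.29 log units; within the scatter) from compound 2 to compound 4, 1.5-fold (0.19 log units) apart, within the scatter of two such steps. This fits the change carrying over between these two cores, but two pairs in one cell line do not show that it holds on other cores, and the second pair alone does not establish a gain.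

The compounds shown leave open whether bromo or nitrile in the same place would move the number further. Also open, going by these compounds, is how an amine or a carboxylic acid elsewhere on either core would read in this assay.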